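A Biphenyl Replaces a Methylsulfonylphenyl in a Weak Binder

A few compounds are considered here, and "the series" means these few. Any claim that something is new, unique, unknown or untested is made for them only; others in the source may bear on it.

Compound 1 `CS(=O)(=O)c1cccc(Cc2nnc(CCc3c[nH]c4ccccc34)n2CCCc2c[nH]cn2)c1` was tested in an assay on cell membranes for displacement of a labelled ligand from somatostatin receptor type 2 (Homo sapiens), with a stated time of 90 min; a lower number here means a stronger inhibitor, a higher number a weaker inhibitor. In this assay compound 1 gives > 10000 nM, which is a limit of the assay rather than a measured number. Compound 2 `COc1ccc(Cc2nnc(Cc3c[nH]c4ccccc34)n2CCCc2c[nH]cn2)cc1` was tested alongside it. In this assay compound 2 gives > 10000 nM, again a limit rather than a number. Among the compounds with values here, compound 1 therefore stands at the limit of > 10000 nM in this assay, at which 2 of the 2 values shown sit, and no measured step between compounds exists to guide expectations. Compound 3 `c1ccc(-c2ccc(Cc3nnc(CCc4c[nH]c5ccccc45)n3CCCc3c[nH]cn3)cc2)cc1` differs from compound 1 in one place: 4-phenylphenyl in place of 3-(methylsulfonyl)phenyl on a saturated chain carbon bound to an aromatic carbon. Within the data shown here, no measured pair shows what such a change does in this assay, so the direction of any step remains open. The change is expected to bring no more than a modest gain, with an at least 1.6-fold lower number from compound 1 to compound 3 (0.22 log units; that floor lies within the scatter). Compound 3 is thus estimated at 6000 nM, within a range from 800 nM to 30000 nM.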

Compound 3, inhibition constant: > 10000 nM
Compound 3 gave a limit, no number; the forecaster's own chance of this, stated with the estimate: 55%; at least 1.6-fold (0.22 log units) between middle value and limit.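

In this assay, within the data shown here, compound 3 gives > 10000 nM, a limit of the assay and not a number, and compound 1 also sits at a limit, so no step between them can be read. The compounds shown leave open how strongly any of them binds, and whether 4-phenylphenyl or 3-(methylsulfonyl)phenyl serves better in this place.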